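A few compounds are considered here, and "the series" means these few. Any claim that something is new, unique, unknown or untested is made for them only; others in the source may bear on it.

Working notes on the nitro-for-hydrogen step in this series.

Compound 1 `CCN(CC)C(=O)C1CCCN(c2c(F)cc3c(=O)c(C(=O)O)cn(C4CC4)c3c2OC)C1` gives 136000 nM in an ADME assay on Vero cells (Chlorocebus sabaeus) for cytotoxicity, read by MTT assay, with a stated time of 72 h; a lower number here means a stronger inhibitor, a higher number a weaker inhibitor. Compound 3 `CCN(CC)C(=O)C1CCCN(c2c(F)c([N+](=O)[O-])c3c(=O)c(C(=O)O)cn(C4CC4)c3c2OC)C1` differs from it by nitro in place of hydrogen on an aromatic carbon and gives 124000 nM in this assay; the step of a 1.1-fold lower number from compound 1 to compound 3 (0.04 log units; within the scatter) is within the scatter, so the nitro group leaves the read-out essentially unchanged on the core of compound 1.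

Compound 2 `COc1c(N2CCc3ccccc3C2C(=O)NC(C)(C)C)c(F)cc2c(=O)c(C(=O)O)cn(C3CC3)c12` carries a different core; how the two cores differ is not broken down here. In this assay compound 2 is recorded as "not determined" (no result reported), so no number is available for it.

Compound 4 `COc1c(N2CCc3ccccc3C2C(=O)NC(C)(C)C)c(F)c([N+](=O)[O-])c2c(=O)c(C(=O)O)cn(C3CC3)c12` differs from compound 2 by nitro in place of hydrogen on an aromatic carbon, the same change as from compound 1 to compound 3, at the same place. Since that step was within the scatter, a step of similar size is expected from compound 2 to compound 4, though no value for compound 2 anchors it. Compound 4 is estimated at 130000 nM in this assay, with a range of 50000 nM to 300000 nM.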

Compound 4, half-maximal inhibitory concentration: 113000 nM
For compound 4 the middle estimate is 1.2-fold (0.06 log units) above the measured one, within the range that was stated.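

Among the compounds shown here, compound 2 carries no number in this assay, so no step to compound 4 can be read. The compounds shown leave open whether nitro in place of hydrogen acts alike on both cores. No supporting evidence bears on this result.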